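This account rests on a few compounds, and the source may have more. Where it says the series, first, only, none or still open, it means among the compounds named here.

Measured in a functional assay on KB cells (Homo sapiens) for antiproliferative activity, read by sulforhodamine B assay, with a stated time of 48 h; a higher number here means a weaker inhibitor of growth, a lower number a stronger inhibitor of growth:
- compound 1 `Nc1ccccc1NC(=O)c1ccc(CCc2ccccc2NS(=O)(=O)c2ccc(F)cc2)cc1` gives 884 nM
- compound 2 `N#Cc1ccc(S(=O)(=O)Nc2ccccc2CCc2ccc(C(=O)Nc3ccccc3N)cc2)cc1` gives 790 nM
- compound 3 `COc1ccc(S(=O)(=O)Nc2ccccc2CCc2ccc(C(=O)Nc3ccccc3)cc2)cc1` gives 137 nM

Compound 3 has the lowest number of the three in this assay and is the starting point for compound 4 `COc1ccc(S(=O)(=O)Nc2ccccc2CCc2ccccc2)cc1`, which has hydrogen in place of phenylcarbamoyl on an aromatic carbon. Among the compounds with values here, the only measured step is cyano in place of fluoro (a 1.1-fold lower number from compound 1 to compound 2 (0.05 log units; within the scatter)), and it lies within the scatter. Within the data shown here, it involves a different group, so no measured step gives the size of this change. Starting from the low value of compound 3 (137 nM), a higher number is expected once the large group is gone, though its size is poorly defined. The expected step is wide (an 11-fold higher number from compound 3 to compound 4 (1.04 log units; beyond the scatter)). Compound 4 is estimated at 1500 nM within 250 nM to 9000 nM as the expected range.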

Compound 4, concentration for 50% growth inhibition: 4410 nM
The estimate for compound 4 lay 2.9-fold (0.47 log units) below the measured number; low and high end bracket the measured number.
By their numbers in this assay, from the lowest: compound 3; then compounds 2 and 1 (each within the scatter of the next); then compound 4.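

In this assay, the change shows a 32-fold higher number from compound 3 to compound 4 (1.51 log units; beyond the scatter) at this aromatic carbon, so growth inhibition here depends strongly on what occupies the position. Within the data shown here, the only earlier step, cyano in place of fluoro, lay within the scatter and at a different place, so it gave no sign of a change this large. No available measurement explains the loss of activity.

Going by these compounds, whether the carbonyl, the amide hydrogen or the outer phenyl ring carries the effect stays open. It is also unknown whether a carboxylic acid or a simple amine at this carbon would keep any of the activity of compound 3.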